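Shortening the Hydroxamate Linker in a Prostate Cell Series

The source may report more compounds than this note shows. Statements on the series, on what has been measured and on what is new or still open speak of the compounds shown alone.

Compound 1, `C#CCN(C)Cc1ccc(NC(=O)CCCCC(=O)NO)cc1`: > 10000 nM
Compound 2, `C#CCN(C)Cc1ccc(NCc2ccc(/C=C/C(=O)NO)cc2)cc1`: 560 nM

In a functional assay on DU-145 cells (Homo sapiens) for inhibition, read by MTT assay, with a stated time of 48 h (a higher number here means a weaker inhibitor of growth, a lower number a stronger inhibitor of growth), compound 1 gives > 10000 nM, which is a limit of the assay rather than a number (the limit of > 10000 nM in this assay, at which 1 of the 2 values shown sits). Compound 2 gives 560 nM in this assay, and this is the only number shown. The value of compound 1 is a limit, so compound 2 cannot be ranked against compound 1. Compound 3, `C#CCN(C)Cc1ccc(NCc2ccc(C(=O)NO)cc2)cc1`, has not yet been measured. It differs from compound 2 in one place: hydroxycarbamoyl in place of 2-(hydroxycarbamoyl)ethenyl on an aromatic carbon. Among the measured compounds shown here, no step between two measured compounds exists to gauge how such a change plays out here, so the expectation rests on the structures alone. The step from compound 2 to compound 3 is expected to weaken growth inhibition beyond the usual scatter, a 4.5-fold higher number from compound 2 to compound 3 (0.65 log units; beyond the scatter). Compound 3 is therefore estimated to give 2500 nM in this assay, with a likely range from 800 nM to 8000 nM.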

Compound 3, concentration for 50% growth inhibition: > 10000 nM
Compound 3 was reported as a limit; the forecaster's own chance of this, stated with the estimate: 15%; middle value at least 4.0-fold (0.60 log units) from the limit.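

In this assay, among the compounds shown here, dropping the ethenyl link so that hydroxycarbamoyl sits directly on the aromatic carbon gives the first step in this set that can be read, and it is large: an at least 17-fold higher number from compound 2 to compound 3 (1.25 log units; beyond the scatter). This shows that, at this position on the ring, the 2-(hydroxycarbamoyl)ethenyl group of compound 2 cannot be shortened to hydroxycarbamoyl without a clear loss of growth inhibition. The value of compound 3 is a limit and not a number, so the step has a known minimum but no known full size, and limits now dominate the set: the limit of > 10000 nM in this assay, at which 2 of the 3 values shown sit.

The compounds shown leave open whether the double bond or only the length of the link counts, which a saturated ethyl link ending in hydroxycarbamoyl could separate. They also leave open how a carboxylic acid in place of the hydroxycarbamoyl would behave at this position.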